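A Benzyl to 4-Methylphenyl Swap on the Amide-Type Nitrogen

The source may hold more compounds than are shown below. What is called first, only, known or untested is meant among the compounds shown, and "the series" means these compounds.

Measured compounds:
- compound 1, `N#Cc1ccc(CN(C(=O)Nc2cc(C(F)(F)F)cc(C(F)(F)F)c2)n2cnnc2)cc1`, gives 7220 nM
- compound 2, `COc1ccc(CN(C(=O)Nc2ccc(C#N)cc2)n2cnnc2)cc1OC`, gives > 50000 nM
- compound 3, `O=C(NCc1ccccc1)N(Cc1ccccn1)n1cnnc1`, gives > 50000 nM

These values come from a functional assay on MCF7 cells (Homo sapiens) for cytotoxicity, read by MTT assay, with a stated time of 48 h; a lower number here means a stronger inhibitor, a higher number a weaker inhibitor. For compound 3 the result is only a limit, > 50000 nM, and not a measured number. The same is true of compound 2, whose value of > 50000 nM is also a limit. The one full number in the set belongs to compound 1, at 7220 nM, so compound 3 sits at the weak end of what is shown, alongside compound 2, with both resting at the limit of > 50000 nM in this assay, at which 2 of the 3 values shown sit.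

Compound 4, `Cc1ccc(NC(=O)N(Cc2ccccn2)n2cnnc2)cc1`, has not yet been measured in this assay. It differs from compound 3 in one place: 4-methylphenyl in place of benzyl on an amide-type nitrogen. Going by the values given here, no step between two measured compounds covers this kind of change, and the only full number, that of compound 1, belongs to a compound built differently in several places.

With compound 3 itself sitting at a limit, the step from compound 3 to compound 4 is expected to stay small, an at least 1.4-fold lower number from compound 3 to compound 4 (0.15 log units; that floor lies within the scatter), most likely within the scatter or giving at best a modest gain. Compound 4 is therefore estimated at 35000 nM, within a range of 8000 nM to 150000 nM, with a fair chance that this assay again reports only a limit for compound 4.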

Compound 4, half-maximal inhibitory concentration: 38900 nM
For compound 4 the middle estimate is 1.1-fold (0.05 log units) below the measured one, within the range that was stated.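

In this assay, going by these compounds alone, 4-methylphenyl in place of benzyl on an amide-type nitrogen gives the first readable step at this position: an at least 1.2-fold lower number from compound 3 to compound 4 (0.10 log units; that floor lies within the scatter). Within the data shown here, compound 4 gives 38900 nM, a full number with the rest of compound 3 left unchanged, whereas the only earlier full number belonged to compound 1, which is built differently in several places. Going by these compounds, the printed step is only a floor and its true size stays unknown, since the result for compound 3 is a limit and not a number: the limit of > 50000 nM in this assay, at which 2 of the 4 values shown sit.

The compounds shown do not separate the part played by the methyl group from the part played by attaching the ring directly to the nitrogen, which a plain phenyl at this place would help to tell apart. They also leave open how this assay would respond to a longer chain in place of benzyl, or to a phenyl carrying an amine or a carboxylic acid in place of the methyl group.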